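Chloro in Place of Fluoro on a Weak Dioxygenase Inhibitor

The source may hold more compounds than are shown below. What is called first, only, known or untested is meant among the compounds shown, and "the series" means these compounds.

For the measured compounds named here, in an assay on isolated protein for inhibition of Indoleamine 2,3-dioxygenase 1 (Homo sapiens), read by spectrophotometry (a higher number here means a weaker inhibitor, a lower number a stronger inhibitor), compound 2 `O/N=C(/Nc1ccc(F)c(F)c1)c1ccc2occc2c1` gives 22700 nM, the only measured number in this small set. Compound 1 `O/N=C(/Nc1ccc(Cl)cc1)c1ccc2occc2c1` gives > 30000 nM, a limit of the assay rather than a number. Compound 3 `O/N=C(/Nc1ccc(Cl)c(F)c1)c1ccc2occc2c1` has not yet been measured; it differs from compound 2 by chloro in place of fluoro on an aromatic carbon. No measured step of this kind is shown, so the expected shift a 1.1-fold higher number from compound 2 to compound 3 (0.04 log units; within the scatter) is taken as none beyond the usual scatter. On that basis compound 3 is estimated at 25000 nM in this assay, with a likely range from 10000 nM to 60000 nM, and a real chance that only a limit is returned.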

Compound 3, half-maximal inhibitory concentration: > 30000 nM
Compound 3 ended at the assay's limit (the forecaster's own chance of this, stated with the estimate: 40%); middle value at least 1.2-fold (0.07 log units) from the limit.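

In this assay, chloro in place of fluoro, at the place para to a large group and ortho to a fluoro group, gives an at least 1.3-fold higher number from compound 2 to compound 3 (0.12 log units; that floor lies within the scatter). Compound 3 returns a limit and not a number, so this step has a floor only, and chloro here brings no measurable gain over fluoro. The step from compound 1 to compound 3 cannot be read, because both compounds sit at the same limit: the limit of > 30000 nM in this assay, at which 2 of the 3 values shown sit.

Going by these compounds, whether the full size of the chloro step lies beyond the scatter remains open. So does how a methoxy group or an amine would read at this place.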